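A few compounds are considered here, and "the series" means these few. Any claim that something is new, unique, unknown or untested is made for them only; others in the source may bear on it.

Measured so far:
- compound 1 `COC(=O)c1ccc(NCC2Cc3c(N)nc(N)nc3NC2=O)cc1`: > 20 ug/mL
- compound 2 `COC(=O)c1ccc(CCC2Cc3c(N)nc(N)nc3NC2=O)cc1`: > 20 ug/mL
- compound 3 `CN(CC1Cc2c(N)nc(N)nc2NC1=O)c1ccc(C(=O)O)cc1`: > 20 ug/mL

All three readings come from a functional assay on CCRF-CEM cells (Homo sapiens) for inhibition (on this read-out lower numbers stand for stronger inhibition and higher numbers for weaker inhibition), and none of them is a number. In this series the whole picture is one line: the limit of > 20 ug/mL in this assay, at which 3 of the 3 values shown sit. Compound 1 stands at > 20 ug/mL, which is a limit of the assay. Among the measured compounds shown here, no measured compound therefore gives a reference value, and no step between measured compounds can be sized.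

The next entry is compound 4 `Nc1nc(N)c2c(n1)NC(=O)C(CNc1ccc(C(=O)O)cc1)C2`, which keeps the shared core and the amino linker of compound 1. The change is hydrogen in place of methyl on an oxygen next to a carbonyl group, or methoxycarbonyl to carboxy.

For the measured compounds named here, with no measured step to draw on, the expectation in this assay is no shift beyond the scatter, in either direction. The closest guide is compound 3, which also carries a carboxy group and reads > 20 ug/mL, again only a limit. The expected size of the move is a step that the limit leaves unreadable from compound 1 to compound 4, and a reading that is again only a limit is the likeliest result. The estimated value for compound 4 is 30 ug/mL, with an expected range of 12 ug/mL to 60 ug/mL.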

Compound 4, half-maximal inhibitory concentration: > 20 ug/mL
Compound 4: a limit, no number; the forecaster's own chance of this, stated with the estimate: 85%; the middle value does not contradict the limit.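

In this assay compound 4 gives > 20 ug/mL, which is a limit and not a number. Neither the step from compound 1 to compound 4 nor the step from compound 3 to compound 4 can be read, and the series stays on one line: the limit of > 20 ug/mL in this assay, at which 4 of the 4 values shown sit.

The compounds shown leave open whether methoxycarbonyl to carboxy changes inhibition at all.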